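The source may hold more compounds than are shown below. What is called first, only, known or untested is meant among the compounds shown, and "the series" means these compounds.

Three ureas share one core and differ only in the group on one aromatic carbon. Compound 1 `CC(C)c1cccc(C(C)C)c1NC(=O)NCC1(c2ccc(F)cc2)CCCC1` carries fluoro there and in an assay on microsomes for inhibition of acyl-CoA:cholesterol acyltransferase (Oryctolagus cuniculus) (a higher number here means a weaker inhibitor, a lower number a stronger inhibitor), compound 1 gives 23 nM. Compound 2 `CC(C)c1cccc(C(C)C)c1NC(=O)NCC1(c2ccc(OCc3ccccc3)cc2)CCCC1` carries benzyloxy, and compound 2 gives 34 nM in this assay. Compound 3 `CC(C)c1cccc(C(C)C)c1NC(=O)NCC1(c2ccc([N+](=O)[O-])cc2)CCCC1` carries nitro, and compound 3 gives 131 nM in this assay, the highest of the three numbers: the steps of a 5.7-fold higher number from compound 1 to compound 3 (0.76 log units; beyond the scatter) and a 3.9-fold higher number from compound 2 to compound 3 (0.59 log units; beyond the scatter) both lie beyond the scatter, whereas a 1.5-fold higher number from compound 1 to compound 2 (0.17 log units; within the scatter) does not. Compound 4 `CC(C)c1cccc(C(C)C)c1NC(=O)NCC1(c2ccc(N)cc2)CCCC1` is the next member, with the change (amino in place of nitro on an aromatic carbon). Among the measured compounds shown here, no measured pair covers an amino group at this carbon; what the two steps onto nitro show is that an exchange at this position can move the number beyond the scatter, and that nitro sits at the weak end of the three. An amino group there is expected to give a modest step back toward the fluoro and benzyloxy numbers, and the expected step is a 2.2-fold lower number from compound 3 to compound 4 (0.34 log units; beyond the scatter). Compound 4 is estimated at 60 nM, with a range from 20 nM to 200 nM.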

Compound 4, half-maximal inhibitory concentration: 29 nM
Compound 4: middle estimate off by 2.1-fold (0.32 log units), on the high side, and the stated range covers the measured number.
By their numbers in this assay, from the lowest: compounds 1, 4 and 2 (each within the scatter of the next); then compound 3.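

In this assay the position proves reversible: amino in place of nitro gives a 4.5-fold lower number from compound 3 to compound 4 (0.65 log units; beyond the scatter) and so removes the gap that nitro had opened. Amino also falls in with the other two groups, with a 1.3-fold higher number from compound 1 to compound 4 (0.10 log units; within the scatter) and a 1.2-fold lower number from compound 2 to compound 4 (0.07 log units; within the scatter) both within the scatter, so that among these four compounds the fluoro, benzyloxy and amino compounds cannot be told apart and only nitro in compound 3 stands off from them. Nothing given here bears on why the nitro compound separates from the rest.

The compounds shown leave open whether a nitrile or a carboxylic acid on this carbon would stay with the nitro compound or join the other three. They also leave open whether an acetamide or a dimethylamino group would keep the number seen with amino.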